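Replacing sec-butyl with phenyl: what compound 4 may show

The compounds below may be only part of what the source reports. "The series", "measured", "known", "first", "only" and "open" are said of these compounds alone.

Measured in a functional assay on K562 cells (Homo sapiens) for cytotoxicity, read by MTT assay, with a stated time of 48 h; on this read-out lower numbers stand for stronger inhibition and higher numbers for weaker inhibition:
compound 1 `C=C[C@@]1(C)COC(=O)[C@]12OC([C@H](C)CC)=CC2=O`: 47.1 ug/mL
compound 2 `C=C[C@@]1(C)COC(=O)C1(O)C(=O)/C=C(\O)c1ccccc1`: 33.7 ug/mL
compound 3 `C=C[C@@]1(C)COC(=O)C1C(=O)/C=C(\O)c1ccccc1`: 20 ug/mL

Compound 1 lies within the scatter of compound 2, and its number is clearly higher than that of compound 3. Compound 4 `C=C[C@@]1(C)COC(=O)[C@]12OC(c1ccccc1)=CC2=O` keeps the core of compound 1 but carries phenyl in place of sec-butyl on a double-bonded ring carbon. Going by the values given here, no measured step makes this change. The only one, a 1.7-fold lower number from compound 2 to compound 3 (0.23 log units; within the scatter), concerns a different swap, so it says little here. Compound 3, which also carries a phenyl, gives 20 ug/mL, but its core differs, so this is only a weak hint towards a lower number. The estimated change, likely not beyond the scatter, is a 1.5-fold lower number from compound 1 to compound 4 (0.17 log units; within the scatter). Compound 4 is expected at about 32 ug/mL, with an estimated range of 13 ug/mL to 75 ug/mL.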

Compound 4, half-maximal inhibitory concentration: 32.8 ug/mL
Compound 4: middle estimate off by 1.0-fold (0.01 log units), on the low side; measured number inside the range.
By their numbers in this assay, from the lowest: compounds 3, 4, 2 and 1 (each within the scatter of the next, the first and the last beyond it).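

Placing phenyl on this double-bonded ring carbon gives a 1.4-fold lower number from compound 1 to compound 4 (0.16 log units; within the scatter) in this assay, the first direct reading of a change at this position. On the core of compound 1, sec-butyl and phenyl therefore cannot be told apart in this assay, even though phenyl brings a six-membered aromatic ring. Nothing available explains this result.

The compounds shown leave open how an amine, a carboxylic acid or a longer chain would read on this ring carbon, and whether any group here could shift the number beyond the scatter.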